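Cytotoxicity notes on ester variants of a shared core

This account rests on a few compounds, and the source may have more. Where it says the series, first, only, none or still open, it means among the compounds named here.

Compound 1 `O=C(OCCc1c(-c2ccccc2Cl)c2cc(Cl)ccc2[nH]c1=O)c1ccccc1`: 43000 nM
Compound 2 `O=C(COc1ccccc1)OCCc1c(-c2ccccc2Cl)c2cc(Cl)ccc2[nH]c1=O`: 81000 nM

In an ADME assay on HepG2 2.2.15 cells (Homo sapiens) for cytotoxicity (on this read-out higher numbers stand for lower toxicity in this test and lower numbers for higher toxicity in this test), compound 2 gives 81000 nM, and compound 1 lies within the scatter of it, so the pair sits at one level. Among the measured compounds shown here, compound 3 `O=C(/C=C/c1cccc(F)c1)OCCc1c(-c2ccccc2Cl)c2cc(Cl)ccc2[nH]c1=O` has no measurement yet. Its difference from compound 2 is 2-(3-fluorophenyl)ethenyl in place of phenoxymethyl on a carbonyl carbon. In words, this is 2-(3-fluorophenyl)ethenyl in place of phenoxymethyl on a carbonyl carbon. For the measured compounds named here, the only measured step at this place is a 1.9-fold higher number from compound 1 to compound 2 (0.28 log units; within the scatter), with phenoxymethyl in place of phenyl. That step stayed within the scatter. Going by the values given here, no measured compound carries the entering group, so the evidence is thin. No step beyond the scatter is expected in this assay, in either direction. For compound 3 the expected value is 60000 nM, with an estimated range of 25000 nM to 130000 nM. This means an expected 1.4-fold lower number from compound 2 to compound 3 (0.13 log units; within the scatter).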

Compound 3, half-maximal cytotoxic concentration: > 1600000 nM
Compound 3: only a limit was reported; the forecaster's own chance of this, stated with the estimate: 15%; middle value at least 26-fold (1.42 log units) away from the limit.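

In this assay compound 3 carries a limit and not a number: the limit of > 1600000 nM in this assay, at which 1 of the 3 values shown sits.

On the carbonyl carbon, 2-(3-fluorophenyl)ethenyl in place of phenoxymethyl gives an at least 19-fold higher number from compound 2 to compound 3 (1.29 log units; beyond the scatter), and in place of phenyl it gives an at least 37-fold higher number from compound 1 to compound 3 (1.57 log units; beyond the scatter). The earlier step, a 1.9-fold higher number from compound 1 to compound 2 (0.28 log units; within the scatter), gave no sign that this position could move the read-out beyond the scatter, whereas the two new steps show that it can, towards lower toxicity in this test, with the full size of the change left open by the limit.

With a single compound carrying the entering group, the ethenyl link and the fluorine cannot be told apart. As far as these compounds go, whether a plain 2-phenylethenyl or a saturated 2-phenylethyl on the same carbonyl carbon would keep this level remains open.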